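Notes on the step to compound 4

The source may hold more compounds than are shown below. What is called first, only, known or untested is meant among the compounds shown, and "the series" means these compounds.

Measured in a functional assay on B16-F10 cells (Mus musculus) for antiproliferative activity, read by CCK-8 assay, with a stated time of 48 h; a higher number here means a weaker inhibitor, a lower number a stronger inhibitor:
- compound 1 `COc1ccc(/C=C\c2cc(OC)c(OC)c(OC)c2)cc1OCc1ccc(CN2CCCC[C@H]2C(=O)O)cc1`: > 10000 nM (a limit)
- compound 2 `COc1ccc(/C=C\c2cc(OC)c(OC)c(OC)c2)cc1OCc1ccc(CNCCO)cc1`: 6600 nM
- compound 3 `COc1ccc(/C=C\c2cc(OC)c(OC)c(OC)c2)cc1OCc1ccc(CNCCN(C)C)cc1`: > 10000 nM (a limit)

Compound 3 has no number in this assay, only the limit > 10000 nM. The series is bounded here by the limit of > 10000 nM in this assay, at which 2 of the 3 values shown sit.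

The next compound, compound 4 `COc1ccc(/C=C\c2cc(OC)c(OC)c(OC)c2)cc1OCc1ccc(CN2CC[C@@H](C(=O)O)C2)cc1`, carries 3-carboxypyrrolidin-1-yl in place of (2-(dimethylamino)ethyl)amino on a saturated chain carbon bound to an aromatic carbon.

Compound 1 also carries a carboxy group on a non-aromatic ring, so the closest measured change is a step that the two limits leave unreadable from compound 1 to compound 3. The other two, an at least 1.5-fold lower number from compound 1 to compound 2 (0.18 log units; that floor lies within the scatter) and an at least 1.5-fold higher number from compound 2 to compound 3 (0.18 log units; that floor lies within the scatter), give floors within the scatter. With compound 1 at its limit of > 10000 nM, no step beyond the scatter is expected in this assay, in either direction. The estimated step is a step that the limit leaves unreadable from compound 3 to compound 4. Compound 4 is estimated at 12000 nM, with an expected range of 5000 nM to 30000 nM. A reading that gives only a limit is the likeliest outcome.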

Compound 4, half-maximal inhibitory concentration: > 10000 nM
Compound 4: no number, only a limit (the forecaster's own chance of this, stated with the estimate: 70%); the middle value is on the limit's open side.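

In this assay, the 3-carboxypyrrolidin-1-yl group on the saturated chain carbon bound to an aromatic carbon gives a limit rather than a number, as the 2-carboxypiperidin-1-yl group of compound 1 does, so neither group carrying a carboxy on a non-aromatic ring gives a measured value here. Among these compounds, the one readable step is an at least 1.5-fold higher number from compound 2 to compound 4 (0.18 log units; that floor lies within the scatter), and the other two new steps cannot be read. No measured ranking of these groups emerges at this position, and the series stays bounded by this: the limit of > 10000 nM in this assay, at which 3 of the 4 values shown sit.

On these data alone, whether a methyl ester of the carboxylic acid, a primary amine or a longer hydroxyalkyl chain would read clearly apart from compound 2 at 6600 nM stays open. As far as these compounds go, how the opposite configuration at the stereocentre of compound 4 would read also stays open.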